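This account rests on a few compounds, and the source may have more. Where it says the series, first, only, none or still open, it means among the compounds named here.

Measured compounds:
- compound 1, `COc1ccc(N)c(C2=NN(C(=O)C3CC3)C(C)(C)S2)c1`, gives 90.1% in an assay on isolated protein for inhibition of Nitric oxide synthase, inducible (Homo sapiens), read by scintillation counting, with a stated time of 30 min, tested at 50 uM; on this read-out lower numbers stand for less inhibition and higher numbers for more inhibition at the one concentration tested (going by the name of the read-out)
- compound 2, `CC(=O)N1N=C(c2cc(Cl)ccc2N)SC1(C)C`, gives 72.8% in this assay
- compound 3, `CCCCC(=O)N1N=C(c2cc(Cl)ccc2N)SC1(C)C`, gives 12.6% in this assay

Compound 3 stands lowest of the three measured numbers; compound 2 is its nearest neighbour, beyond the scatter, and compound 1 is furthest away. Going by the values given here, the only measured step that changes the group on the carbonyl carbon is the one from compound 2 to compound 3, a number 60.2 percentage points lower from compound 2 to compound 3 (beyond the scatter), where a longer chain took the place of hydrogen and inhibition fell sharply.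

Compound 4, `CC1(C)SC(c2cc(Cl)ccc2N)=NN1C(=O)C1CC1`, has not yet been measured in this assay. It differs from compound 3 in one place: cyclopropyl in place of butyl on a carbonyl carbon. This reverses the direction of the measured step, moving away from the butyl that accompanied the low number of compound 3. Compound 1, which also carries a cyclopropyl on a carbonyl carbon, though with a different group on its aromatic ring, gives the highest number of the set. A large upward step is therefore expected, a number 57.4 percentage points higher from compound 3 to compound 4 (beyond the scatter). Compound 4 is estimated at 70%, with a range from 40% to 95%.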

Compound 4, a percentage reported as inhibition, at one concentration (the size of the read-out at that concentration, not a potency): 23.2%
Estimate against measurement, compound 4: 46.8 percentage points above; the measured number lies below the stated range.
By their numbers in this assay, from the lowest: compound 3; then compound 4; then compound 2; then compound 1.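

Cyclopropyl on the carbonyl carbon recovers only a little of what butyl lost, a number 10.6 percentage points higher from compound 3 to compound 4 (beyond the scatter) in this assay, and it remains far from the methyl of the same chloro series, with a number 49.6 percentage points lower from compound 2 to compound 4 (beyond the scatter) as the step. So among these three compounds with the chloro group, methyl alone gives a high number, and replacing the open butyl chain with a cyclopropyl ring changes little by comparison. The high number of compound 1 therefore does not come from the cyclopropylcarbonyl group alone, since the aromatic group matters greatly here, as a number 66.9 percentage points lower from compound 1 to compound 4 (beyond the scatter) shows for chloro in place of methoxy.

As far as these compounds go, it remains open whether methoxy would lift the methyl and butyl compounds as well, and what ethyl, cyclobutyl or an amine would give on the carbonyl carbon. Nothing available explains why these numbers differ.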